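The source may report more compounds than this note shows. Statements on the series, on what has been measured and on what is new or still open speak of the compounds shown alone.

Of the compounds shown here, three of one shared core have been measured in a functional assay on the whole organism with Rattus norvegicus as the target; a lower number here means that less compound is needed, a higher number that more compound is needed for the effect. Compound 1 `CC(C)(C)Cc1ccc2nc(N)sc2c1` reaches only the limit of the assay, giving > 10 mg/kg, which is a limit and not a number. Compound 2 `Nc1nc2ccc(CC(F)(F)F)cc2s1` gives 8 mg/kg. The change from the first to the second is an at least 1.2-fold lower number from compound 1 to compound 2 (0.09 log units; that floor lies within the scatter). Compound 3 `CCCn1c(=N)sc2cc(OC(F)(F)F)ccc21` gives 4.5 mg/kg, the lowest of the two real numbers, with compound 2 as its nearest neighbour at a gap that also lies within the scatter, so the two cannot be ranked.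

Compound 4 `CS(=O)(=O)CCn1c(=N)sc2cc(OC(F)(F)F)ccc21` differs from compound 3 in one place: methylsulfonyl in place of methyl on a saturated chain carbon, two bonds along the chain from an aromatic nitrogen. Going by the values given here, no measured step covers this exchange; the only measured step, that from compound 1 to compound 2, is a different group at a different place, and its size stays within the scatter. There is therefore nothing in the measured data to point in either direction. The expectation for compound 4 is a number close to that of compound 3, with the step of a 1.1-fold higher number from compound 3 to compound 4 (0.05 log units; within the scatter) not expected to exceed the scatter. Compound 4 is estimated at 5 mg/kg, between 2 mg/kg and 15 mg/kg.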

Compound 4, dose for half-maximal effect: 1.8 mg/kg
Compound 4: middle estimate off by 2.8-fold (0.44 log units), on the high side, and the stated range ends above it.
By their numbers in this assay, from the lowest: compound 4; then compounds 3 and 2 (each within the scatter of the next). At a limit, above all of these: compound 1.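

In this assay, methylsulfonyl in place of methyl on this saturated chain carbon, two bonds along the chain from an aromatic nitrogen, gives a 2.5-fold lower number from compound 3 to compound 4 (0.40 log units; beyond the scatter) and so provides the only step among these compounds that lies beyond the scatter. The position therefore accepts a much larger end group: four heavy atoms enter where one leaves, and two hydrogen-bond acceptors enter where there were none, yet less compound is needed for the effect, not more. Nothing measured here tells which feature of the entering group accounts for this step.

From the compounds shown here alone, whether the sulfur group itself matters stays open, as a simple ether, an amine or a carboxylic acid at the same place could show. A longer chain between the aromatic nitrogen and the methylsulfonyl group is equally untested by the compounds shown.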